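Compound 4: pentyl in place of cyclobutyl

The compounds below may be only part of what the source reports. "The series", "measured", "known", "first", "only" and "open" are said of these compounds alone.

Compounds measured so far in an ADME assay on MRC5 cells (Homo sapiens) for inhibition, with a stated time of 72 h; a higher number here means that more compound is needed for the effect, a lower number that less compound is needed:
compound 1 `CO[C@H]1CC[C@H](NC(=O)c2n[nH]cc2NC(=O)c2c(C)nc3ccccn23)CC1`: 34000 nM
compound 2 `COc1cccc(OC)c1C(=O)Nc1c[nH]nc1C(=O)NC1CCC1`: > 50000 nM
compound 3 `CO[C@H]1CC[C@H](NC(=O)c2n[nH]cc2NC(=O)c2cnc3ccccn23)CC1`: 5900 nM

Compound 2 stands at > 50000 nM, which is a limit of the assay and not a number. What stands for it is therefore (the limit of > 50000 nM in this assay, at which 1 of the 3 values shown sits), and any step from compound 2 starts from that limit rather than from a true value.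

Compound 4 `CCCCCNC(=O)c1n[nH]cc1NC(=O)c1c(OC)cccc1OC` has not yet been measured. It differs from compound 2 in one place: pentyl in place of cyclobutyl on an amide-type nitrogen. The two groups are open chain and ring forms of similar size, pentyl in place of cyclobutyl on an amide-type nitrogen.

For the measured compounds named here, only one measured step is available, a 5.8-fold lower number from compound 1 to compound 3 (0.76 log units; beyond the scatter). That step is hydrogen in place of methyl on an aromatic carbon, so it is not the change made here and bears on it only indirectly. It shows that a single change can carry a value in this assay modestly beyond the scatter. Going by the values given here, no measured step alters the group on the amide-type nitrogen.

A modest step is therefore expected, towards a lower number if any number is reported at all. The estimated step is an at least 1.4-fold lower number from compound 2 to compound 4 (0.15 log units; that floor lies within the scatter). For compound 4 the estimate is 35000 nM, with an expected range from 12000 nM to 50000 nM.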

Compound 4, half-maximal effective concentration: > 50000 nM
Compound 4: only a limit was reported (the forecaster's own chance of this, stated with the estimate: 45%); at least 1.4-fold (0.15 log units) between middle value and limit.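

In this assay compound 4 gives > 50000 nM, which is a limit of the assay and not a number. No step from compound 2 to compound 4 can be read, because both compounds rest on a limit: the limit of > 50000 nM in this assay, at which 2 of the 4 values shown sit.
The compounds shown leave open whether pentyl in place of cyclobutyl on an amide-type nitrogen changes the value at all, and in which direction.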